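The source may hold more compounds than are shown below. What is called first, only, known or untested is meant among the compounds shown, and "the series" means these compounds.

Series notes, compounds sharing an aryl ether to a fused bicyclic core, carrying a pyrimidine with a cyclic amine on the far side.

Within the data shown here, compound 1 `CN(c1ccc(Oc2ncnc3ccsc23)cc1)c1nccc(N2CCCC2)n1` is the first reference. In a functional assay on A549 cells (Homo sapiens) for inhibition, read by MTT assay, with a stated time of 72 h, tested at 20 uM (a lower number here means less inhibition, a higher number more inhibition at the concentration tested (going by the name of the read-out)), compound 1 gives 63.9%. Compound 2 `CN(c1ccc(Oc2ncnc3ccsc23)cc1)c1nccc(N2CCc3ccccc3C2)n1` keeps the core of compound 1 and differs only in the cyclic amine: 1,2,3,4-tetrahydroisoquinolin-2-yl in place of pyrrolidin-1-yl on an aromatic carbon. In this assay compound 2 gives 69.9%. The step in this assay is a number 6 percentage points higher from compound 1 to compound 2 (within the scatter), so the two numbers sit within the usual scatter of one another and nothing about order can be read from them.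

Compound 3 `c1cc(N2CCCC2)nc(Nc2ccc(Oc3ncnc4sccc34)cc2)n1` has a different core from compound 1; the difference between the two cores is not broken down here. In this assay compound 3 gives 61%, a number that lies within the scatter of both compound 1 and compound 2.

Compound 4 `c1ccc2c(c1)CCN(c1ccnc(Nc3ccc(Oc4ncnc5sccc45)cc3)n1)C2` is not yet measured. It stands to compound 3 as compound 2 stands to compound 1: 1,2,3,4-tetrahydroisoquinolin-2-yl in place of pyrrolidin-1-yl on an aromatic carbon. The place of the change is described in the same words for both pairs, so this is the same change made on the second core.

Expectation for compound 4 in this assay rests on compound 1 and compound 2, where the same change gave a number 6 percentage points higher from compound 1 to compound 2 (within the scatter). The step from compound 3 is therefore expected to be a number 5 percentage points higher from compound 3 to compound 4 (within the scatter), with the difference from compound 3 staying inside the scatter of the read-out. For compound 4 the estimate is 66%, with a range from 55% to 77%.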

Compound 4, a percentage reported as inhibition, at one concentration (the size of the read-out at that concentration, not a potency): 34%
Compound 4: the middle estimate sits 32 percentage points above what was measured; measured number outside the range, below it.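

In this assay, the change of pyrrolidin-1-yl to 1,2,3,4-tetrahydroisoquinolin-2-yl gives a number 27 percentage points lower from compound 3 to compound 4 (beyond the scatter), and this does not repeat the earlier step: the same change on two cores in this assay, a number 6 percentage points higher (within the scatter) from compound 1 to compound 2 and a number 27 percentage points lower (beyond the scatter) from compound 3 to compound 4, 33 percentage points apart, beyond the scatter of two such steps The result of this change on the core of compound 1 therefore cannot be carried over as a fixed increment to the core of compound 3, and in this series the outcome of the change depends on the core it is made on, as far as these two pairs go. It does not show which difference between the two cores matters or why the pairs part, and it rests on one pair per core, each read as a percentage at a single concentration, which says nothing about potency.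

The compounds shown leave open whether a piperidin-1-yl or morpholin-4-yl group on the same aromatic carbon would stay with compound 3 on its core or fall towards compound 4, which would separate the six-membered ring from the fused aromatic ring. Also open, going by these compounds, is how the change behaves on a core that carries only one of the features separating the two cores, such as the core of compound 3 with a methyl group on the linking nitrogen.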